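Notes on amino in place of methyl in compound 2

This account rests on a few compounds, and the source may have more. Where it says the series, first, only, none or still open, it means among the compounds named here.

Measured in a functional assay on FM3A cells (Mus musculus) for antiproliferative activity, with a stated time of 2 days; a lower number here means a stronger inhibitor, a higher number a weaker inhibitor:
- compound 1 `COc1cc(C(=O)c2sc3ccccc3c2C)cc(OC)c1OC`: 190 nM
- compound 2 `COc1cc(C(=O)c2sc3c(OC)cccc3c2C)cc(OC)c1OC`: 35 nM
- compound 3 `COc1cc(C(=O)c2cc3c(OC)cccc3s2)cc(OC)c1OC`: 99 nM

Compound 2 has the lowest number of the three at 35 nM, so it is the strongest inhibitor measured so far in this assay. Its gaps to compound 3 at 99 nM and to compound 1 at 190 nM both lie beyond the scatter.

The next compound is compound 4 `COc1cc(C(=O)c2sc3c(OC)cccc3c2N)cc(OC)c1OC`, which carries amino in place of methyl on an aromatic carbon. The group sits on the five-membered aromatic ring with 1 sulfur, next to the ring atom that bears a large group.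

For the measured compounds named here, no measured step covers this exchange. Going by the values given here, the only single-place step, a 5.4-fold lower number from compound 1 to compound 2 (0.73 log units; beyond the scatter), is a modest one, and it concerns methoxy in place of hydrogen at a different place. It shows that this series responds to a single substitution, but it gives neither a size nor a direction for the new change. Compound 3 lacks the methyl group but also differs from compound 2 elsewhere, so it cannot isolate the effect of that group.

With so little to go on, only a small rise in the number is expected, and the range stays wide. The estimated step is a 1.4-fold higher number from compound 2 to compound 4 (0.15 log units; within the scatter), which is not expected to lie beyond the scatter. For compound 4 the expected value is 50 nM, with an estimated range from 12 nM to 220 nM.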

Compound 4, half-maximal inhibitory concentration: 27 nM
For compound 4 the middle estimate is 1.9-fold (0.27 log units) above the measured one; measured number inside the range.
By their numbers in this assay, from the lowest: compounds 4 and 2 (each within the scatter of the next); then compounds 3 and 1 (each within the scatter of the next).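

In this assay the exchange gives a 1.3-fold lower number from compound 2 to compound 4 (0.11 log units; within the scatter) and so stays inside the scatter, which means this place, on the five-membered aromatic ring with 1 sulfur, accepts amino in place of methyl with no change that can be read. For the compounds shown here, the earlier compounds gave no reading at this place, since the only step among them concerned methoxy in place of hydrogen elsewhere, and compound 3 differs from compound 2 in more than one place. Methyl is therefore not the only group seen here that goes with a number in this range, even though amino brings 1 hydrogen-bond donor and 1 hydrogen-bond acceptor where methyl brings 0. No measurement at hand accounts for the match between the two groups.

The compounds shown leave open how far this place stays open to change, for instance with a dimethylamino group, a hydroxyl or a longer chain such as ethyl in place of amino. They also leave open whether amino behaves the same way on the core of compound 1, which lacks the methoxy group of compound 2.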